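Swapping the Dimethoxyphenyl Group of Compound 3

This account rests on a few compounds, and the source may have more. Where it says the series, first, only, none or still open, it means among the compounds named here.

Three related compounds share one core and differ in their side groups. In a functional assay on HeLa cells (Homo sapiens) for cytotoxicity, read by MTT assay, with a stated time of 72 h (on this read-out lower numbers stand for stronger inhibition and higher numbers for weaker inhibition), compound 1 (`COc1ccc(OC)c(/C=C/C(=O)Nc2cc3c(Nc4ccc(F)c(Cl)c4)ncnc3cc2OC)c1`) has "not determined" (no result reported) as its entry. Compound 2 (`COc1ccc(/C=C/C(=O)Nc2cc3c(Nc4ccc(F)c(Cl)c4)ncnc3cc2OC)c(OC)c1`) likewise has "not determined" (no result reported) as its entry in this assay so it offers no comparison either. Going by the values given here, compound 3 (`COc1ccc(OC)c(/C=C/C(=O)Nc2cc3c(Nc4ccc(F)c(Cl)c4)ncnc3cc2O[C@H]2CCOC2)c1`) gives 26800 nM in this assay and is the only compound with a number, so it cannot be ranked against the others.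

Still untested is compound 4 (`COc1cc(/C=C/C(=O)Nc2cc3c(Nc4ccc(F)c(Cl)c4)ncnc3cc2O[C@H]2CCOC2)cc(OC)c1O`), which carries 4-hydroxy-3,5-dimethoxyphenyl in place of 2,5-dimethoxyphenyl on a double-bonded chain carbon bound to a double-bonded chain carbon. Among the compounds with values here, no two measured compounds differ in one place only, so the data give no direct guide to the size of this swap. Within the data shown here, the sole anchor is compound 3 at 26800 nM and that makes any forecast loose. A modest step toward stronger inhibition is expected, an estimated 1.8-fold lower number from compound 3 to compound 4 (0.25 log units; within the scatter) in this assay and the direction is uncertain. In this assay the estimated value for compound 4 is 15000 nM (expected range 4000 nM to 50000 nM).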

Compound 4, half-maximal inhibitory concentration: 27400 nM
Compound 4: the middle estimate sits 1.8-fold (0.26 log units) below what was measured, and the stated range covers the measured number.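

In this assay, going by these compounds alone, putting 4-hydroxy-3,5-dimethoxyphenyl in place of 2,5-dimethoxyphenyl on a double-bonded chain carbon bound to a double-bonded chain carbon gives a 1.0-fold higher number from compound 3 to compound 4 (0.01 log units; within the scatter), the first step that can be read at this position. The entering group carries a hydrogen-bond donor that the leaving group lacks, yet the two compounds cannot be told apart on this read-out, so this particular swap leaves the number where it was. No measurement shown here offers an explanation for this result.

From the compounds shown here alone, it remains open whether any group at this position can shift the number, for example a phenyl ring bearing an amine or a carboxylic acid. Also open, going by these compounds, is how a longer chain in place of the double-bonded chain would behave in this assay on this same core.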